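A few compounds are considered here, and "the series" means these few. Any claim that something is new, unique, unknown or untested is made for them only; others in the source may bear on it.

Working notes on the series. Going by the values given here, compound 1 `C=C1CC[C@@H]2[C@](C)(CCC[C@]2(C)C(=O)OC)[C@H]1CCc1ccc2c(OC)ccc(OC)c2c1` is the first of two close analogues. In a functional assay on A549 cells (Homo sapiens) for cytotoxicity, read by sulforhodamine B assay, with a stated time of 72 h (a higher number here means a weaker inhibitor of growth, a lower number a stronger inhibitor of growth), compound 1 reaches only a limit, > 6700 nM. Compound 2 `C=C1[C@H](O)C[C@@H]2[C@](C)(CCC[C@]2(C)C(=O)OC)[C@H]1CCc1ccc2c(OC)ccc(OC)c2c1` differs from compound 1 by hydroxy in place of hydrogen on a saturated ring carbon. In this assay compound 2 likewise stops at a limit, > 6400 nM. The step that the two limits leave unreadable from compound 1 to compound 2 cannot be sized due to the limit of > 6700 nM in this assay, at which 1 of the 3 values shown sits, and (the limit of > 6400 nM in this assay, at which 1 of the 3 values shown sits).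

Compound 3 `COC(=O)[C@@]1(C)CCC[C@]2(C)C(CCc3ccc4c(OC(C)=O)ccc(OC(C)=O)c4c3)=C(C)CC[C@@H]12` stands on a different core; how the two cores differ is not broken down here. In this assay, among the compounds with values here, compound 3 gives 240 nM, the only plain number among the three measured values.

Compound 4 `COC(=O)[C@@]1(C)CCC[C@]2(C)C(CCc3ccc4c(OC(C)=O)ccc(OC(C)=O)c4c3)=C(C)[C@@H](O)C[C@@H]12` is derived from compound 3 by hydroxy in place of hydrogen on a saturated ring carbon. This is the same kind of change as from compound 1 to compound 2, though not the same: in compound 4 the hydroxy sits next to the ring atom that bears a methyl group, a feature the earlier place does not state. The earlier step offered no readable size, so the step from compound 3 to compound 4 is estimated as roughly neutral, a 1.3-fold higher number from compound 3 to compound 4 (0.10 log units; within the scatter), with wide uncertainty. Compound 4 is accordingly expected at 300 nM, within 100 nM to 1200 nM.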

Compound 4, concentration for 50% growth inhibition: 4800 nM
Compound 4: middle estimate off by 16-fold (1.20 log units), on the low side; the measured number lies above the stated range.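

On the second core, hydroxy in place of hydrogen on a saturated ring carbon gives, in this assay, a 20-fold higher number from compound 3 to compound 4 (1.30 log units; beyond the scatter), so at this place the change goes with a much weaker inhibitor of growth. The step from compound 1 to compound 2 cannot be read, since both compounds stop at limits, so there is no size to set beside the new step, and carrying the change between cores is neither confirmed nor refuted: the limit of > 6700 nM in this assay, at which 1 of the 4 values shown sits. The two places are also not shown to be equal, as the hydroxy of compound 4 sits next to the ring atom that bears a methyl group, a feature not stated for compound 2, so the result holds only for this place on this core.

From the compounds shown here alone, whether an amine or a carboxylic acid on the same ring carbon would go the same way as hydroxy stays open. Also open, going by these compounds, is whether hydroxy on the opposite face of the ring would give the same result.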